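The source may hold more compounds than are shown below. What is called first, only, known or untested is meant among the compounds shown, and "the series" means these compounds.

Compound 3 `CCCCCc1cc2nn(-c3ccccc3)cc2c(C)n1` was tested in a functional assay on K562 cells (Homo sapiens) for inhibition, read by fluorescence, with a stated time of 72 h (a lower number here means a stronger inhibitor of growth, a higher number a weaker inhibitor of growth), where compound 3 gives 6900 nM. Compound 2 `Cc1nc(-c2ccccc2)cc2nn(-c3ccccc3)cc12` gives 6300 nM in this assay, and the step of a 1.1-fold higher number from compound 2 to compound 3 (0.04 log units; within the scatter) shows that the two numbers lie within the scatter of each other, so neither can be called the stronger. Compound 1 `CC(C)c1nccc2nn(-c3ccccc3)cc12` gives only a limit in this assay, > 100000 nM, namely (the limit of > 100000 nM in this assay, at which 1 of the 3 values shown sits).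

Compound 4 `Cc1nccc2nn(-c3ccccc3)cc12` has not yet been measured. It differs from compound 3 by hydrogen in place of pentyl on an aromatic carbon, in words hydrogen in place of pentyl on an aromatic carbon. Going by the values given here, only one measured step touches that carbon, a 1.1-fold higher number from compound 2 to compound 3 (0.04 log units; within the scatter), which swaps pentyl for phenyl and stays within the scatter; it says nothing about removing the group entirely. Among the compounds with values here, compound 1 likewise carries hydrogen in place of pentyl or phenyl, but it also differs from compound 4 in a second place, and it gives no number in this assay; it shows only that a compound without the group can be a weak inhibitor of growth. Compound 4 is therefore expected to be a weaker inhibitor of growth, by an estimated step of an 8.7-fold higher number from compound 3 to compound 4 (0.94 log units; beyond the scatter). Compound 4 is estimated at 60000 nM in this assay, within a range from 15000 nM to 200000 nM.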

Compound 4, concentration for 50% growth inhibition: > 100000 nM
Compound 4 ended at the assay's limit; the forecaster's own chance of this, stated with the estimate: 45%; at least 1.6-fold (0.22 log units) between middle value and limit.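

Up to now, swapping pentyl for phenyl on this aromatic carbon had shown only that the two groups cannot be told apart in this assay; the new result shows that a group at this place matters at all. Hydrogen in place of pentyl gives an at least 14-fold higher number from compound 3 to compound 4 (1.16 log units; beyond the scatter), and hydrogen in place of phenyl gives an at least 15-fold higher number from compound 2 to compound 4 (1.20 log units; beyond the scatter), so either group, a chain or a ring, separates compound 4 from the two measurable compounds by a large step. The value of compound 4 is a limit, so these steps fix only a smallest size, and the steps between the two compounds at the limit cannot be read: the limit of > 100000 nM in this assay, at which 2 of the 4 values shown sit.

The compounds shown leave open how much of the group this carbon needs, as nothing stands between hydrogen and pentyl here, such as an ethyl or propyl chain, and nothing shows whether an amine or a carboxylic acid at the end of such a chain would keep the growth inhibition. They also leave open what isopropyl does in place of methyl, as it appears only in compound 1, which carries neither pentyl nor phenyl.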